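This account rests on a few compounds, and the source may have more. Where it says the series, first, only, none or still open, it means among the compounds named here.

Measured compounds:
compound 1, `O=C(Nc1cccc(-c2oc3cc(-c4ccc(F)cc4)ccc3c(=O)c2O)c1)c1ccccc1F` — 17400 nM
compound 2, `Cc1cccc(C(=O)Nc2cccc(-c3oc4cc(-c5ccc(F)cc5)ccc4c(=O)c3O)c2)c1` — 10900 nM
compound 3, `CCc1ccc(C(=O)Nc2cccc(-c3oc4cc(-c5ccc(F)cc5)ccc4c(=O)c3O)c2)cc1` — 24600 nM

All three were tested in a functional assay on GTL 16 cells for antiproliferative activity against GTL 16 cell line (Homo sapiens), read by CCK-8 assay, with a stated time of 72 h; on this read-out higher numbers stand for weaker inhibition and lower numbers for stronger inhibition. Compound 3 gives the highest number of the three: its gap to compound 1 is within the scatter, while a 2.3-fold higher number from compound 2 to compound 3 (0.35 log units; beyond the scatter) is modest but real. Compound 4, `COc1cc(OC)cc(C(=O)Nc2cccc(-c3oc4cc(-c5ccc(F)cc5)ccc4c(=O)c3O)c2)c1`, differs from compound 3 only in the group on the carbonyl carbon: 3,5-dimethoxyphenyl in place of 4-ethylphenyl on a carbonyl carbon. Among the compounds with values here, the steps that bear on this change are a 1.6-fold lower number from compound 1 to compound 2 (0.20 log units; within the scatter), a 1.4-fold higher number from compound 1 to compound 3 (0.15 log units; within the scatter) and a 2.3-fold higher number from compound 2 to compound 3 (0.35 log units; beyond the scatter), all small; swapping one aryl group on this carbonyl for another has so far moved the numbers little. Within the data shown here, no measured compound carries methoxy groups there, so the expectation for compound 4 is a step of about a 1.6-fold lower number from compound 3 to compound 4 (0.21 log units; within the scatter), not clearly beyond the scatter. Compound 4 is therefore estimated at 15000 nM, with a likely range from 5000 nM to 45000 nM.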

Compound 4, half-maximal inhibitory concentration: 19600 nM
For compound 4 the middle estimate is 1.3-fold (0.12 log units) below the measured one, and the stated range covers the measured number.
By their numbers in this assay, from the lowest: compounds 2, 1, 4 and 3 (each within the scatter of the next, the first and the last beyond it).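

In this assay, within the data shown here, 3,5-dimethoxyphenyl is the first group on this carbonyl carbon to carry hydrogen-bond acceptors, yet compound 4 stays within the scatter of all three earlier compounds (with a 1.3-fold lower number from compound 3 to compound 4 (0.10 log units; within the scatter) and a 1.8-fold higher number from compound 2 to compound 4 (0.25 log units; within the scatter) and a 1.1-fold higher number from compound 1 to compound 4 (0.05 log units; within the scatter)). Adding methoxy groups to the aryl ring at this position therefore produces no readable change. No evidence is available to explain this flat result. Every compound shown keeps an aryl group on this carbonyl carbon, so the effect of an amine, a carboxylic acid or a longer alkyl chain there remains open.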